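The source may hold more compounds than are shown below. What is called first, only, known or untested is meant among the compounds shown, and "the series" means these compounds.

Within the data shown here, the two compounds measured so far share one core and differ only in what sits on the outer aromatic ring. Compound 1 `Cc1cccc(-c2cnc(Nc3cccc4c3CC(O)CC4)o2)c1` gives 157 nM in an in vitro functional assay on cells for antagonist activity at transient receptor potential cation channel subfamily V member 1 (Homo sapiens), read by FLIPR and calcium flux; on this read-out lower numbers stand for stronger inhibition and higher numbers for weaker inhibition. Compound 2 `CC(C)(C)c1ccc(-c2cnc(Nc3cccc4c3CC(O)CC4)o2)cc1` gives 26 nM in this assay, the lower of the two numbers, and the gap to compound 1, its nearest neighbour, lies beyond the usual scatter. Compound 3 `OC1CCc2cccc(Nc3ncc(-c4ccc(Cl)cc4)o3)c2C1` has not been measured in this assay yet. It differs from compound 2 in one place: chloro in place of tert-butyl on an aromatic carbon. Among the measured compounds shown here, no measured pair shows this exchange, so the size of the step can only be judged. A moderate rise in the number, meaning weaker inhibition, seems the more likely outcome, though a result within the scatter of compound 2 cannot be ruled out. Compound 3 is therefore expected to give about 80 nM, somewhere between 25 nM and 250 nM, which would mean an expected step of a 3.1-fold higher number from compound 2 to compound 3 (0.49 log units; beyond the scatter) in this assay.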

Compound 3, half-maximal inhibitory concentration: 15 nM
Estimate against measurement, compound 3: 5.3-fold (0.73 log units) above; the whole stated range lies above it.
By their numbers in this assay, from the lowest: compounds 3 and 2 (each within the scatter of the next); then compound 1.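

In this assay, chloro in place of tert-butyl gives a 1.7-fold lower number from compound 2 to compound 3 (0.24 log units; within the scatter), so a single chlorine atom serves this position as well as a group of 4 heavy atoms, and the position does not depend on the larger group. The other new comparison, a 10-fold lower number from compound 1 to compound 3 (1.02 log units; beyond the scatter), is large, but 4-chlorophenyl in place of 3-methylphenyl changes both the group and its place on the ring, so this one pair cannot show which of the two changes matters. No measurement shown here explains either step.

On these data alone, it remains open whether a methyl group on the same carbon would match chloro, which would separate the effect of the group from the effect of its place. It is also unknown how an amine, a methoxy group or a carboxylic acid would fare there.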